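The source may report more compounds than this note shows. Statements on the series, on what has been measured and on what is new or still open speak of the compounds shown alone.

Measured so far in an ADME assay on microsomes from liver (Rattus norvegicus) for metabolic stability; on this read-out higher numbers stand for a more stable compound and lower numbers for a less stable compound:
Compound 1 `CCCCCOC(=O)N1CCN(C(=O)[C@H](CCC(=O)O)NC(=O)c2cc(N3CCC(OCCO)CC3)nc(-c3ccccc3)n2)CC1` reaches a limit of the assay, > 80%.
Compound 2 `CCCCCOC(=O)N1CCN(C(=O)[C@H](CCC(=O)O)NC(=O)c2nc(-c3ccccc3)cc(N3CCC(CN)CC3)n2)CC1` likewise reaches a limit, > 80%.
Compound 3 `CCCCCOC(=O)N1CCN(C(=O)[C@H](CCC(=O)O)NC(=O)c2nc(-c3ccccc3)cc(N3CCC(COC)CC3)n2)CC1` also reaches a limit, > 80%.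

Compound 1 therefore stands at a limit, not at a number, and the two further values shown do the same; all three sit at the limit of > 80% in this assay, at which 3 of the 3 values shown sit. Compound 4 `CCCCCOC(=O)N1CCN(C(=O)[C@H](CCC(=O)O)NC(=O)c2cc(N3CCC(C(N)=O)CC3)nc(-c3ccccc3)n2)CC1` differs from compound 1 by carbamoyl in place of 2-hydroxyethoxy on a saturated ring carbon. Within the data shown here, the only measured step that bears on it, a step that the two limits leave unreadable from compound 2 to compound 3, gives no readable size because the limit of > 80% in this assay, at which 3 of the 3 values shown sit, holds both of its ends. No step beyond the scatter is expected; the estimated step that the limit leaves unreadable from compound 1 to compound 4 lies within it. Compound 4 is thus expected at 88%, from 72% to 100%, most likely again reported only as the limit.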

Compound 4, percent of the compound remaining: > 80%
Compound 4: only a limit was reported; the forecaster's own chance of this, stated with the estimate: 80%; the middle value is on the limit's open side.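

In this assay no step can be read from compound 1 to compound 4 because both values are limits: the limit of > 80% in this assay, at which 4 of the 4 values shown sit. On these data alone, how compound 1, compound 2, compound 3 and compound 4 rank in stability remains open.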